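Shortened linker with methoxyphenyl entry in the anilino series

The source may report more compounds than this note shows. Statements on the series, on what has been measured and on what is new or still open speak of the compounds shown alone.

Measured so far:
compound 1 `Nc1cccc(-c2cn3nc(CCc4ccccc4)sc3n2)c1` — 242000 nM
compound 2 `C=C(Br)C(=O)Nc1cccc(-c2cn3nc(-c4cccc(OC)c4)sc3n2)c1` — 1100 nM

Two compounds have numbers in a functional assay on HeLa cells (Homo sapiens) for inhibition, read by cell counting, with a stated time of 4 days; a higher number here means a weaker inhibitor, a lower number a stronger inhibitor. Compound 1 `Nc1cccc(-c2cn3nc(CCc4ccccc4)sc3n2)c1` gives 242000 nM in this assay, the highest of the two numbers shown. Its nearest neighbour is compound 2 `C=C(Br)C(=O)Nc1cccc(-c2cn3nc(-c4cccc(OC)c4)sc3n2)c1`, which in this assay gives 1100 nM, a far lower number and a gap well beyond the scatter. Compound 2 differs from compound 1 in more than one place, so that gap is not a single step and nothing can be attributed to any one change.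

Compound 3 `COc1cccc(Cc2nn3cc(-c4cccc(N)c4)nc3s2)c1` is not yet measured. It differs from compound 1 in one place: 3-methoxyphenyl in place of benzyl on a saturated chain carbon bound to an aromatic carbon. Within the data shown here, no measured pair shows this change on its own, so the expectation rests only on the two values above. The step from compound 1 to compound 3 in this assay is expected to be a 2.4-fold lower number from compound 1 to compound 3 (0.38 log units; beyond the scatter), a lowering beyond the scatter but nowhere near the number of compound 2. Compound 3 is expected to give 100000 nM in this assay, with a range from 20000 nM to 500000 nM.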

Compound 3, half-maximal inhibitory concentration: 24000 nM
For compound 3 the middle estimate is 4.2-fold (0.62 log units) above the measured one; low and high end bracket the measured number.
By their numbers in this assay, from the lowest: compound 2; then compound 3; then compound 1.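

In this assay, among these compounds, 3-methoxyphenyl in place of benzyl on a saturated chain carbon bound to an aromatic carbon gives a 10-fold lower number from compound 1 to compound 3 (1.00 log units; beyond the scatter) and is the first single-place step, showing that this position responds to the nature of the group it carries, though the step is modest. The change happens in one place but is not a single feature, since the entering group has 8 heavy atoms against 7 and 1 hydrogen-bond acceptor against 0, and the step cannot divide its effect among these differences. No measurement at hand explains the step.

Going by these compounds, how much of the step belongs to the methoxy group alone remains open, as does what a plain phenyl, a 3-hydroxyphenyl or a longer chain would give at this place. Also open, on these data alone, is whether the step holds when an acetamide replaces the free amine of compound 3 and compound 1, so that the effect of this position can be read apart from that group.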